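The source may report more compounds than this note shows. Statements on the series, on what has been measured and on what is new or still open speak of the compounds shown alone.

In a functional assay on the whole organism (strain Swiss CD-1) with Mus musculus as the target, with a stated time of 2 h (a higher number here means that more compound is needed for the effect, a lower number that less compound is needed), compound 1 `COCC(C(=O)N1CCN(c2ccc(F)cc2)CC1)N1C(=O)CCC1=O` gives 71.4 mg/kg, compound 2 `COCC(C(=O)N1CCN(c2ccc(C)cc2)CC1)N1C(=O)CCC1=O` gives 21.1 mg/kg and compound 3 `COC[C@H](C(=O)N1CCN(c2ccc(C(F)(F)F)cc2)CC1)N1C(=O)CCC1=O` gives 21.1 mg/kg, the same figure as compound 2, the two sharing the lowest number of the three. Compound 4 `COCC(C(=O)N1CCN(c2ccc(C(F)(F)F)cc2)CC1)N1C(=O)CCC1=O` differs from compound 3 in one way only: the two compounds have the same atoms and bonds; at least one stereo element is drawn with a configuration in one of them and without one in the other: 1 of 1 stereo elements differ; a stereocentre at a saturated chain carbon is drawn R in compound 3 and without a configuration in compound 4. Going by the values given here, the single measured step, a 3.4-fold lower number from compound 1 to compound 2 (0.53 log units; beyond the scatter), swaps fluoro for methyl on an aromatic carbon, so it does not speak directly to a stereocentre. Among the compounds with values here, no measured pair shows what this kind of change does. Taking compound 3 at 21.1 mg/kg as the anchor, the expected change is small, a 1.2-fold higher number from compound 3 to compound 4 (0.07 log units; within the scatter), with no clear direction beyond the scatter. For compound 4 the estimated value is 25 mg/kg, with an expected range of 12 mg/kg to 50 mg/kg.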

Compound 4, dose for half-maximal effect: 22.4 mg/kg
For compound 4 the middle estimate is 1.1-fold (0.05 log units) above the measured one; the range from low to high includes it.
By their numbers in this assay, from the lowest: compounds 2, 3 and 4 (each within the scatter of the next); then compound 1.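

In this assay the step of a 1.1-fold higher number from compound 3 to compound 4 (0.03 log units; within the scatter) shows no readable effect of drawing the saturated chain carbon as R rather than leaving it without a configuration. On the aromatic carbon, the step of a 1.1-fold higher number from compound 2 to compound 4 (0.03 log units; within the scatter) puts trifluoromethyl level with methyl, while the step of a 3.2-fold lower number from compound 1 to compound 4 (0.50 log units; beyond the scatter) sets fluoro apart from trifluoromethyl. The comparison at the chain carbon rests on one difference: the fact that one of compounds 3 and 4 is drawn with a defined configuration and the other without, at the place where they differ.

From the compounds shown here alone, what a compound drawn S would give stays open. So does whether a chloro or methoxy group on that aromatic carbon would sit with fluoro or with methyl.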